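Methyl for Fluoro in the Thiazole Series of Compound 2

The compounds below may be only part of what the source reports. "The series", "measured", "known", "first", "only" and "open" are said of these compounds alone.

Compound 1, `Cc1cc(OCc2ncc(-c3ccccc3)o2)ccc1OCC(=O)O`: > 10000 nM
Compound 2, `Cc1nc(-c2ccc(F)cc2)sc1COc1ccc2c(c1)OCC2CC(=O)O`: 79 nM

In an assay on CHO cells for agonist activity at Free fatty acid receptor 1 (Homo sapiens), read by FLIPR (a higher number here means that more compound is needed for the effect, a lower number that less compound is needed), compound 1 gives > 10000 nM, which is a limit of the assay and not a number. Compound 1 therefore sits at the limit of > 10000 nM in this assay, at which 1 of the 2 values shown sits. For the measured compounds named here, compound 2 gives 79 nM in this assay and so holds the only number among the two values.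

Compound 3, `Cc1ccc(-c2nc(C)c(COc3ccc4c(c3)OCC4CC(=O)O)s2)cc1`, has not yet been measured. It differs from compound 2 by methyl in place of fluoro on an aromatic carbon. Going by the values given here, no measured pair shows this change, so its size is open. The step of a 1.2-fold lower number from compound 2 to compound 3 (0.08 log units; within the scatter) is expected to stay within the usual scatter. For compound 3 the estimate in this assay is 65 nM, with a range from 25 nM to 200 nM.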

Compound 3, half-maximal effective concentration: 94 nM
Compound 3: middle estimate off by 1.4-fold (0.16 log units), on the low side; measured number inside the range.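

In this assay the change from 4-fluorophenyl to 4-methylphenyl gives a 1.2-fold higher number from compound 2 to compound 3 (0.08 log units; within the scatter). This is the first pair shown that differs in one place, and it shows that on this aromatic carbon, para to a large group, methyl can stand in place of fluoro without a change beyond the scatter. Nothing measured here bears on why the two groups read alike. From the compounds shown here alone, what stays open is whether a larger group at this position, such as a methoxy, a trifluoromethyl or an amine, would read the same.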